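Swapping a triazole substituent in a pancreatic cancer cell assay

The source may hold more compounds than are shown below. What is called first, only, known or untested is meant among the compounds shown, and "the series" means these compounds.

Compound 1 `CCCCCc1ccc(C#Cc2c(-c3ccc(CCCCC)cc3)oc3nc(=O)n(Cc4cn(-c5ccccc5F)nn4)cc23)cc1` was tested in a functional assay on CFPAC-1 cells (Homo sapiens) for antiproliferative activity, read by MTT assay, with a stated time of 72 h; a higher number here means a weaker inhibitor, a lower number a stronger inhibitor. In this assay compound 1 gives only a limit, > 100000 nM, the same limit described by the limit of > 100000 nM in this assay, at which 1 of the 2 values shown sits. Within the data shown here, a second compound, compound 2 `O=c1nc2oc(C3CC3)c(C#CC3CC3)c2cn1Cc1cn(Cc2ccccc2)nn1`, gives 4590 nM in this assay; it differs from compound 1 in several places, so no single step is known. Compound 3 `CCCCCc1ccc(C#Cc2c(-c3ccc(CCCCC)cc3)oc3nc(=O)n(Cc4cn(Cc5ccccc5)nn4)cc23)cc1` carries one change from compound 1: benzyl in place of 2-fluorophenyl on an aromatic nitrogen. Only a small step is expected, with the direction uncertain, from compound 1 to compound 3 an at least 1.6-fold lower number from compound 1 to compound 3 (0.22 log units; that floor lies within the scatter). Compound 3 is estimated at 60000 nM, between 15000 nM and 200000 nM.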

Compound 3, half-maximal inhibitory concentration: > 100000 nM
Compound 3: only a limit was reported; the forecaster's own chance of this, stated with the estimate: 50%; at least 1.6-fold (0.22 log units) between middle value and limit.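

Among these compounds, compound 1 and compound 3 both give only a limit rather than a number, so no step between them can be read: the limit of > 100000 nM in this assay, at which 2 of the 3 values shown sit. Going by these compounds, whether benzyl in place of 2-fluorophenyl changes the result in this assay stays open.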